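The source may report more compounds than this note shows. Statements on the series, on what has been measured and on what is new or still open speak of the compounds shown alone.

In an ADME assay on HEK293 cells (Homo sapiens) for cytotoxicity, read by resazurin assay, with a stated time of 48 h (a lower number here means that less compound is tolerated, a higher number that more compound is tolerated), compound 3 `CCc1ccc(S(=O)(=O)Nc2ccc(-c3nc4ccccc4o3)cc2)cc1` gives 82000 nM and compound 1 `O=S(=O)(Nc1ccc(-c2nc3ccccc3o2)cc1)c1ccc(Cl)c(C(F)(F)F)c1` gives 69000 nM, two values within the scatter of each other. Compound 2 `CS(=O)(=O)Nc1ccc(-c2nc3ccccc3o2)cc1` reads > 100000 nM, which is a limit of the assay and not a number. Putting 4-ethylphenyl in place of methyl on the sulfonyl sulfur gives an at least 1.2-fold lower number from compound 2 to compound 3 (0.08 log units; that floor lies within the scatter). Compound 4 `O=S(=O)(Nc1ccc(-c2nc3ccccc3o2)cc1)c1ccc(Cl)c(Cl)c1` has 3,4-dichlorophenyl in place of 4-ethylphenyl on that sulfonyl sulfur: 3,4-dichlorophenyl in place of 4-ethylphenyl on a sulfonyl sulfur. Compound 1 at 69000 nM carries yet another group there and stays within the scatter of compound 3, so no change beyond the scatter is expected in this assay. The expected size is a 1.1-fold lower number from compound 3 to compound 4 (0.06 log units; within the scatter). Compound 4 is estimated at 72000 nM, with an expected range of 40000 nM to 100000 nM.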

Compound 4, half-maximal cytotoxic concentration: > 100000 nM
Compound 4: no number, only a limit (the forecaster's own chance of this, stated with the estimate: 15%); middle value at least 1.3-fold (0.14 log units) from the limit.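

Among the compounds with an aromatic ring on the sulfonyl sulfur, only compound 4 sits at a limit of the assay, so such a ring does not by itself bring a measurable number in this assay. The printed floors, an at least 1.2-fold higher number from compound 3 to compound 4 (0.08 log units; that floor lies within the scatter) and an at least 1.4-fold higher number from compound 1 to compound 4 (0.16 log units; that floor lies within the scatter), show no change beyond the scatter, and the step from compound 2 to compound 4 cannot be read. Any true gap stays hidden because of this ceiling: the limit of > 100000 nM in this assay, at which 2 of the 4 values shown sit.

Still open, going by these compounds, is whether an amine or a carboxylic acid on that aromatic ring, or a longer chain on the sulfonyl sulfur, would give a number below the limit.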